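Replacing Cyclopropyl with Methylsulfonyl on Compound 3

A few compounds are considered here, and "the series" means these few. Any claim that something is new, unique, unknown or untested is made for them only; others in the source may bear on it.

In a physicochemical assay for solubility, read by HPLC, using the shake flask method, measured as kinetic solubility, with a stated time of 20 h, at pH 6.5, tested at 200 uM (a lower number here means a less soluble compound, a higher number a more soluble compound), compound 3 (`c1cc(-c2ccnc3ccc(NC4CC4)nc23)ccn1`) gives 90000 nM. That value lies within the scatter of compound 2 (`CS(=O)(=O)c1cccc(-c2ccc3nccc(N4CCNCC4)c3n2)c1`), which gives 165000 nM. Compound 1 (`O=S(=O)(NCC1COC1)c1cccc(-c2ccc3nccc(-c4ccncc4)c3n2)c1`) gives 20000 nM, a lower number, and its gap to compound 3 lies beyond the scatter. Compound 4 (`CS(=O)(=O)Nc1ccc2nccc(-c3ccncc3)c2n1`) carries methylsulfonyl in place of cyclopropyl on a nitrogen on an aromatic ring. For the measured compounds named here, no two measured compounds differ in one place only, so the data offer no direct measure of such a change. In this assay no step beyond the scatter is expected, and the estimated change is a 1.1-fold higher number from compound 3 to compound 4 (0.05 log units; within the scatter). For compound 4 the estimated value is 100000 nM, with an expected range of 35000 nM to 190000 nM.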

Compound 4, solubility: 90000 nM
For compound 4 the middle estimate is 1.1-fold (0.05 log units) above the measured one, and the stated range covers the measured number.
By their numbers in this assay, from the lowest: compound 1; then compounds 3, 4 and 2 (each within the scatter of the next).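

In this assay, the exchange of cyclopropyl for methylsulfonyl on a nitrogen on an aromatic ring shows no change at the digits printed from compound 3 to compound 4 (within the scatter), the only one-place comparison among the compounds shown. At this position, methylsulfonyl brings hydrogen-bond acceptors that cyclopropyl lacks, yet the two compounds remain within the scatter of each other. No evidence is available to explain this result.

On these data alone, whether other groups on this nitrogen, such as an acetyl group, a longer alkyl chain or a carboxylic acid, would behave alike remains open. So does whether the same exchange would read the same way elsewhere on the shared core.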